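Moving the Acid and Dropping the Chlorine on Compound 4

The source may report more compounds than this note shows. Statements on the series, on what has been measured and on what is new or still open speak of the compounds shown alone.

Compound 3 `Cc1c(OCCCCOc2ccc(C(=O)O)cc2Cl)ccc(C(=O)CC(C)C)c1O` gives the highest of the three values recorded in an assay on HEK293 cells for positive allosteric modulation of metabotropic glutamate receptor 3 (Rattus norvegicus), read by thallium flux, with a stated time of 2.5 min (on this read-out higher numbers stand for larger maximal responses and lower numbers for smaller maximal responses), at 62.9%; the nearest, compound 1 `Cc1cc(C(=O)O)ccc1OCCCCOc1ccc(C(=O)CC(C)C)c(O)c1C`, gives 42.1%, and the furthest, compound 2 `COC(=O)c1ccc(OCCCCOc2ccc(C(=O)CC(C)C)c(O)c2C)cc1`, gives 22.7%. Compound 4 `Cc1c(OCCCCOc2cccc(C(=O)O)c2)ccc(C(=O)CC(C)C)c1O` differs from compound 3 by 3-carboxyphenyl in place of 4-carboxy-2-chlorophenyl on an oxygen on a saturated carbon. Going by the values given here, two measured steps bear on this change. The step of a number 20.8 percentage points higher from compound 1 to compound 3 (beyond the scatter) traded a methyl for the chloro that now leaves, so its removal is expected to cost. The step of a number 19.4 percentage points lower from compound 1 to compound 2 (beyond the scatter) shows that reworking the carboxy-bearing ring lowered the response modestly. Among the compounds with values here, no measured compound carries a 3-carboxyphenyl, so the shifted acid is untested. A modest decrease, a number 22.9 percentage points lower from compound 3 to compound 4 (beyond the scatter), is therefore expected. Compound 4 is estimated at 40% in this assay, within 20% to 60%.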

Compound 4, largest response reached (reported as percent of maximum), in percent of the reference or control that the assay uses: 69.9%
Compound 4: the middle estimate sits 29.9 percentage points below what was measured; the whole stated range lies below it.
By their numbers in this assay, from the lowest: compound 2; then compound 1; then compounds 3 and 4 (each within the scatter of the next).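

With 3-carboxyphenyl on the oxygen on a saturated carbon, the response in this assay stays level with that of the 4-carboxy-2-chlorophenyl compound (a number 7 percentage points higher from compound 3 to compound 4 (within the scatter)), so a response of this size does not require the chloro. The same change exceeds both the 4-carboxy-2-methylphenyl compound (a number 27.8 percentage points higher from compound 1 to compound 4 (beyond the scatter)) and the 4-(methoxycarbonyl)phenyl compound (a number 47.2 percentage points higher from compound 2 to compound 4 (beyond the scatter)). Nothing given here explains these differences.

Going by these compounds, the shifted acid and the lost chloro arrive in one change, so their separate shares stay open, and a plain 4-carboxyphenyl would help divide them. On these data alone, whether a primary amide could replace the acid on this ring also remains open.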